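The source may hold more compounds than are shown below. What is called first, only, known or untested is meant among the compounds shown, and "the series" means these compounds.

Measured compounds in a functional assay on CHO cells for agonist activity at Free fatty acid receptor 1 (Homo sapiens), read by a luciferase reporter; on this read-out higher numbers stand for larger maximal responses and lower numbers for smaller maximal responses:
compound 1 `Cc1nc(-c2ccc(C(F)(F)F)cc2)sc1CNc1ccc(CCC(=O)O)cc1` gives 108%;
compound 2 `O=C(O)/C=C/c1ccc(NCc2cccc(Oc3ccccc3)c2)cc1` gives 76%;
compound 3 `CC(Cc1ccc(NCc2cccc(Oc3ccccc3)c2)cc1)C(=O)O` gives 70%.

Compound 1 stands highest of the three values in this assay, with compound 2 and compound 3 both lower by more than the scatter. The unmeasured compound 4 `Cc1nc(-c2ccc(C(F)(F)F)cc2)sc1CNc1ccc(C(C)CC(=O)O)cc1` differs from compound 1 by methyl in place of hydrogen on a saturated chain carbon bound to an aromatic carbon and a saturated chain carbon.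

For the measured compounds named here, the one measured step touching the acid chain, a number 6 percentage points lower from compound 2 to compound 3 (within the scatter), changed the chain while leaving the maximal response within the scatter. That step is not the same change, so it bears only loosely on compound 4, but it gives no sign of a large effect from altering the acid chain. For compound 4 a small step, a number 8 percentage points lower from compound 1 to compound 4 (within the scatter), is therefore expected, not beyond the scatter. Compound 4 is estimated at 100%, between 80% and 115%.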

Compound 4, largest response reached (reported as percent of maximum), in percent of the reference or control that the assay uses: 109%
Compound 4: middle estimate off by 9 percentage points, on the low side; low and high end bracket the measured number.
By their numbers in this assay, from the lowest: compounds 3 and 2 (each within the scatter of the next); then compounds 1 and 4 (each within the scatter of the next).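

In this assay, methyl in place of hydrogen on a saturated chain carbon bound to an aromatic carbon and a saturated chain carbon gives a number 1 percentage points higher from compound 1 to compound 4 (within the scatter), so the maximal response holds with this added carbon on the core of compound 1. For the compounds shown here, the earlier chain step changed a different place in a different pair, so this is the first reading at this carbon. No supporting data explain the result.

Still open, going by these compounds, is whether an ethyl group or a hydroxyl group at this carbon would keep the response.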